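The source may report more compounds than this note shows. Statements on the series, on what has been measured and on what is new or still open speak of the compounds shown alone.

Of the compounds shown here, three sharing one core have been measured in a functional assay on HEL cells (Homo sapiens) for inhibition; a higher number here means a weaker inhibitor, a lower number a stronger inhibitor. Compound 1 `CC(C)c1cc(-c2n[nH]c(=O)n2-c2cccc(C(=O)NCCCCCC(=O)NO)c2)c(O)cc1O` gives 4600 nM and compound 2 `CC(C)c1cc(-c2n[nH]c(=O)n2-c2ccc(C(=O)NCCCCCCC(=O)NO)cc2)c(O)cc1O` gives 4600 nM, so these two stand level with the highest number of the set. Compound 3 `CC(C)c1cc(-c2n[nH]c(=O)n2-c2cccc(NC(=O)CCCCC(=O)NO)c2)c(O)cc1O` gives 1600 nM, a lower number, beyond the usual scatter. Compound 4 `CC(C)c1cc(-c2n[nH]c(=O)n2-c2ccc(C(=O)NCCCCCCCC(=O)NO)cc2)c(O)cc1O` differs from compound 2 in one place: (hydroxycarbamoyl)methyl in place of hydroxycarbamoyl on a saturated chain carbon, six bonds along the chain from an amide-type nitrogen. Going by the values given here, no measured pair shows this change alone, so the starting point is simply compound 2 at 4600 nM. In this assay, the expected step of a 1.1-fold lower number from compound 2 to compound 4 (0.04 log units; within the scatter) stays within the scatter, with no clear direction. For compound 4 the estimated value is 4200 nM, with an expected range from 1600 nM to 11000 nM.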

Compound 4, half-maximal inhibitory concentration: 4600 nM
For compound 4 the middle estimate is 1.1-fold (0.04 log units) below the measured one; low and high end bracket the measured number.
By their numbers in this assay, from the lowest: compound 3; then compounds 1, 2 and 4 (each within the scatter of the next).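

In this assay, placing (hydroxycarbamoyl)methyl where hydroxycarbamoyl stood, on a saturated chain carbon six bonds along the chain from an amide-type nitrogen, gives no change at the digits printed from compound 2 to compound 4 (within the scatter). Going by these compounds alone, this is the first single-place comparison in the set, and it shows that one added carbon at this position leaves the two compounds level. Chain length at this point, over this one step, therefore does not separate them in this assay.

Still open, on these data alone, is whether a much longer chain, or a carboxylic acid in place of the hydroxycarbamoyl end, would separate from compound 2 in this assay. No evidence is available on why these two compounds stand level.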